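A few compounds are considered here, and "the series" means these few. Any claim that something is new, unique, unknown or untested is made for them only; others in the source may bear on it.

Measured compounds: compound 1 `O=C(O)CCN1Cc2ccc(NC(=O)CCCC3CCNCC3)cc2C1=O`, 5900 nM; compound 2 `O=C(O)CCN1Cc2ccc(NC(=O)c3ccc(N4CCNCC4)cc3)cc2C1=O`, 540 nM.

For the measured compounds named here, in a functional assay on a cell-free system (Platelet, plasma, Homo sapiens) for inhibition (a higher number here means a weaker inhibitor, a lower number a stronger inhibitor), compound 1 gives 5900 nM, the highest of the two numbers known here, while compound 2 gives 540 nM, a lower number beyond the usual scatter. Compound 3 `O=C(O)CCCN1Cc2ccc(NC(=O)CCCC3CCNCC3)cc2C1=O` is not yet measured. It differs from compound 1 in one place: carboxymethyl in place of carboxy on a saturated chain carbon, two bonds along the chain from an amide-type nitrogen in a ring. Going by the values given here, no measured pair shows the effect of this change, so its size is open. In this assay a modest rise in the number is expected, as the step of a 1.5-fold higher number from compound 1 to compound 3 (0.18 log units; within the scatter), and compound 3 is estimated at 9000 nM, between 2000 nM and 40000 nM.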

Compound 3, half-maximal inhibitory concentration: 51000 nM
For compound 3 the middle estimate is 5.7-fold (0.75 log units) below the measured one; measured number above the stated range.
By their numbers in this assay, from the lowest: compound 2; then compound 1; then compound 3.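

The acid-bearing chain at this position tolerates little extension in this assay: going from 2-carboxyethyl to 3-carboxypropyl gives an 8.6-fold higher number from compound 1 to compound 3 (0.94 log units; beyond the scatter). Before this result, the two compounds differed only elsewhere and said nothing about this chain, whereas this single change now clearly weakens inhibition. Nothing available explains the loss.

Going by these compounds, it remains open whether a shorter carboxymethyl group on that nitrogen would give a lower number than the 2-carboxyethyl group of compound 1. On these data alone, it is also open whether 3-carboxypropyl would cost as much on compound 2, with its piperazine-bearing side chain.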